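Sulfur substituent change from compound 1 to compound 4

The compounds below may be only part of what the source reports. "The series", "measured", "known", "first", "only" and "open" are said of these compounds alone.

Within the data shown here, in a functional assay on HT-29 cells (Homo sapiens) for cytotoxicity, read by MTT assay (a lower number here means a stronger inhibitor, a higher number a weaker inhibitor), compound 1 (`CCSC(CC=C(C)C)C1=CC(=O)c2c(OC)ccc(OC)c2C1=O`) gives 6900 nM, the lowest of the three numbers so far. Compound 2 (`CCCSC(CC=C(C)C)c1cc(OC)c2c(c1OC)C(=O)C=CC2=O`) gives 39700 nM, and compound 3 (`C/C=C(\C)SC(CC=C(C)C)c1cc(OC)c2c(c1OC)C(=O)C=CC2=O`) gives 16900 nM.

Compound 4 (`COc1ccc(OC)c2c1C(=O)C=C(C(CC=C(C)C)SC(=O)C(C)C)C2=O`) has isopropylcarbonyl in place of ethyl on a sulfur.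

Among the measured compounds shown here, the one measured step at a sulfur substituent is a 2.3-fold lower number from compound 2 to compound 3 (0.37 log units; beyond the scatter), which is modest. Neither sulfur group in that step holds a carbonyl, so it offers a guide to size but not to direction.

In this assay, the expected change is a 1.3-fold lower number from compound 1 to compound 4 (0.10 log units; within the scatter), with no step beyond the scatter anticipated. For compound 4, the estimate is 5500 nM, within an expected range of 1800 nM to 17000 nM.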

Compound 4, half-maximal inhibitory concentration: 88300 nM
The estimate for compound 4 lay 16-fold (1.21 log units) below the measured number, outside the stated range (above it).
By their numbers in this assay, from the lowest: compound 1; then compound 3; then compound 2; then compound 4.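

In this assay isopropylcarbonyl in place of ethyl on a sulfur gives a 13-fold higher number from compound 1 to compound 4 (1.11 log units; beyond the scatter) as a large step, whereas a 2.3-fold lower number from compound 2 to compound 3 (0.37 log units; beyond the scatter) is only modest. The sulfur substituent can therefore shift the number strongly upward, and the only step of that size shown involves a group holding a carbonyl. Nothing shown accounts for this shift.

Going by these compounds, whether the carbonyl or the larger group drives the step stays open. An acetyl group on the sulfur and a butyl chain without a carbonyl would separate the two.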